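Amide variation in a cytotoxicity series

The source may report more compounds than this note shows. Statements on the series, on what has been measured and on what is new or still open speak of the compounds shown alone.

Measured so far:
compound 1 `CCCCNc1nc(N)nc2cccc(C(=O)NC(C)C)c12` — > 25000 nM
compound 2 `CCCCNc1nc(N)nc2cccc(C(=O)N(C)C(C)C)c12` — > 25000 nM

In an ADME assay on HEK293 cells (Homo sapiens) for cytotoxicity, with a stated time of 6 h (a higher number here means that more compound is tolerated, a lower number that less compound is tolerated), compound 1 gives > 25000 nM, which is a limit of the assay and not a number. In this assay compound 2 gives > 25000 nM, again a limit and not a number. For the measured compounds named here, compound 2 therefore stands at the limit, and the one further value shown sits at the same limit (the limit of > 25000 nM in this assay, at which 2 of the 2 values shown sit). Going by the values given here, the single measured step, a step that the two limits leave unreadable from compound 1 to compound 2, has no readable size; both of its ends are limits.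

Compound 3 `CCCCNc1nc(N)nc2cccc(C(=O)N[C@H](C)c3ccccc3)c12` differs from compound 2 in one place: (1-phenylethyl)amino in place of isopropyl(methyl)amino on a carbonyl carbon. Among the compounds with values here, the measured step from compound 1 to compound 2 also altered the amide-type nitrogen, but its size is not readable, so no measured step gives a size for the present change. With both measured values at the limit (the limit of > 25000 nM in this assay, at which 2 of the 2 values shown sit), the expectation for compound 3 is that this assay again reports a value at or near the limit, with no step beyond the scatter in either direction supported. Compound 3 is accordingly estimated at 25000 nM, within 8000 nM to 80000 nM. The expected step of a number no higher from compound 2 to compound 3 (the limit leaves the size open) is small.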

Compound 3, half-maximal cytotoxic concentration: > 25000 nM
Compound 3: a limit, no number (the forecaster's own chance of this, stated with the estimate: 70%); the middle value sits exactly at the limit.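

No step among compound 1, compound 2 and compound 3 can be read, since each value is a limit and not a number: the limit of > 25000 nM in this assay, at which 3 of the 3 values shown sit.

The compounds shown leave open how large the effect of any of these amide changes is in this assay, and whether any amide on the shared core gives a value away from the limit.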